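A Longer Carbon Chain on the Shared Core

The compounds below may be only part of what the source reports. "The series", "measured", "known", "first", "only" and "open" are said of these compounds alone.

For the measured compounds named here, in a functional assay on cells (T-cell line, Homo sapiens) for inhibition (on this read-out lower numbers stand for stronger inhibition and higher numbers for weaker inhibition), compound 3 `CCCCN1CCC(COC(c2ccccc2)c2ccccc2)CC1` gives 14000 nM, the higher of the two actual numbers so far, and compound 2 `COc1ccccc1CCCN1CCC(COC(c2ccccc2)c2ccccc2)CC1` gives 2400 nM. Compound 1 `CN1CCC(COC(c2ccccc2)c2ccccc2)CC1` gives > 20000 nM, which is a limit of the assay and not a number.

Compound 4 `CCCCCCCCN1CCC(COC(c2ccccc2)c2ccccc2)CC1` extends the chain of compound 3, and the change is butyl in place of hydrogen on a saturated chain carbon, four bonds along the chain from an amine nitrogen in a ring. Going by the values given here, no measured step lengthens a plain carbon chain beyond that of compound 3, so the nearest guides are indirect. Adding a carbon chain to the bare core gives an at least 1.4-fold lower number from compound 1 to compound 3 (0.15 log units; that floor lies within the scatter), a floor within the scatter, so the true size of that step remains open. The larger addition, ending in 2-methoxyphenyl, gives an at least 8.3-fold lower number from compound 1 to compound 2 (0.92 log units; beyond the scatter), and this is beyond the scatter. Going back to the shorter chain gives a 5.8-fold higher number from compound 2 to compound 3 (0.77 log units; beyond the scatter). Among the compounds with values here, in these three compounds, a larger group on the nitrogen goes with a lower number, and no compound goes against this, although the evidence is thin. A modest gain is therefore expected, with a 4.0-fold lower number from compound 3 to compound 4 (0.60 log units; beyond the scatter) as the estimated step. For compound 4 the estimated value is 3500 nM, with an expected range from 900 nM to 13000 nM.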

Compound 4, half-maximal inhibitory concentration: 700 nM
For compound 4 the middle estimate is 5.0-fold (0.70 log units) above the measured one, and the stated range ends above it.
By their numbers in this assay, from the lowest: compound 4; then compound 2; then compound 3. At a limit, above all of these: compound 1.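

At this place, four bonds along the chain from an amine nitrogen in a ring, adding butyl to the plain carbon chain gives a 20-fold lower number from compound 3 to compound 4 (1.30 log units; beyond the scatter) in this assay, so chain length alone can shift the number by a large step. A ring at the end of the chain is not needed for a low number in this set, as pentyl in place of 2-methoxyphenyl gives a 3.4-fold lower number from compound 2 to compound 4 (0.54 log units; beyond the scatter) and the plain chain of compound 4 has the lowest number of the four compounds. Compound 1 stands at a limit of the assay and not at a number, so the addition of heptyl to the bare core, which gives an at least 28-fold lower number from compound 1 to compound 4 (1.45 log units; beyond the scatter), sets only a floor for that step: the limit of > 20000 nM in this assay, at which 1 of the 4 values shown sits.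

From the compounds shown here alone, with only two plain chains measured above the limit, it remains open whether a chain longer than that of compound 4 would lower the number further or raise it again. Going by these compounds, it is also open how the number would respond to an amine or a carboxylic acid at the far end of a chain of this length.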